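This account rests on a few compounds, and the source may have more. Where it says the series, first, only, none or still open, it means among the compounds named here.

Compound 1 `COc1ccc(C(N)=O)cc1S(=O)(=O)Nc1cccnc1` carries a carbamoyl group on the shared core. In an assay on isolated protein for inhibition of alkaline phosphatase, tissue-nonspecific isozyme (Homo sapiens) (on this read-out lower numbers stand for stronger inhibition and higher numbers for weaker inhibition), compound 1 gives "not determined" (no result reported), so no number places it on the scale. Compound 2 `COc1ccc(C#N)cc1S(=O)(=O)Nc1cnc2ccccc2c1` likewise returns "not determined" (no result reported) in this assay. Compound 3 `COC(=O)c1cncc(NS(=O)(=O)c2cc(Cl)ccc2OC)c1` gives > 20000 nM in this assay, which is a limit of the assay and not a number. The only quantitative entry in the series is thus (the limit of > 20000 nM in this assay, at which 1 of the 3 values shown sits). Compound 1 therefore stands without a number of its own; beside it there are one limit and one further entry without a number.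

Compound 4 `COc1ccc(Br)cc1S(=O)(=O)Nc1cccnc1` is the next analogue: bromo in place of carbamoyl on an aromatic carbon. Among the compounds with values here, no step between measured compounds exists in this assay, so no measured size guides the change from compound 1 to compound 4. Compound 4 is nonetheless expected to remain weak in this assay because compound 3 sits at the limit of > 20000 nM in this assay, at which 1 of the 3 values shown sits, and any step from compound 1 to compound 4 is expected to be unresolved beyond the scatter. Compound 4 is estimated at 20000 nM, within 5000 nM to 80000 nM, with a fair chance that only a limit is reported.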

Compound 4, half-maximal inhibitory concentration: 543 nM
Compound 4: middle estimate off by 37-fold (1.57 log units), on the high side; measured number below the stated range.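

In this assay compound 1 gives "not determined" (no result reported), so no step can be read between it and compound 4, which gives 543 nM. The compounds shown leave open how much of the value of compound 4 goes with bromo in place of carbamoyl on the shared core.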